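The source may hold more compounds than are shown below. What is called first, only, known or untested is meant among the compounds shown, and "the series" means these compounds.

In a functional assay on MDA-MB-231 cells (Homo sapiens) for inhibition, read by WST assay, with a stated time of 48 h (on this read-out higher numbers stand for weaker inhibition of growth and lower numbers for stronger inhibition of growth), three compounds built on a shared core have been measured. Compound 2 `CC/C=C\C/C=C\C/C=C\C/C=C\C/C=C\C/C=C\CCC(=O)Oc1ccccc1` gives only a limit, > 25000 nM. Compound 1 `CC/C=C\C/C=C\C/C=C\C/C=C\C/C=C\C/C=C\CCC(=O)Oc1ccc(C(C)C)cc1C(C)C` gives 12600 nM and compound 3 `CC/C=C\C/C=C\C/C=C\C/C=C\C/C=C\C/C=C\CCC(=O)Oc1ccccc1C(C)C` gives 12100 nM, so compound 3 stands level with compound 1, within the scatter. Compound 4 `CC/C=C\C/C=C\C/C=C\C/C=C\C/C=C\C/C=C\CCC(=O)Oc1ccccc1C1CCCCC1` carries cyclohexyl in place of isopropyl on an aromatic carbon, (cyclohexyl in place of isopropyl on an aromatic carbon). Going by the values given here, two measured steps bear on this place. Isopropyl in place of hydrogen gave an at least 2.0-fold lower number from compound 2 to compound 3 (0.31 log units; beyond the scatter), while the further change gave a 1.0-fold lower number from compound 1 to compound 3 (0.02 log units; within the scatter). Neither step tests a cyclohexyl group, so only a small change is expected in this assay, an estimated 1.2-fold lower number from compound 3 to compound 4 (0.08 log units; within the scatter). Compound 4 is expected at 10000 nM, within an estimated range of 5000 nM to 20000 nM.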

Compound 4, concentration for total growth inhibition: 18700 nM
Estimate against measurement, compound 4: 1.9-fold (0.27 log units) below; the measured number falls inside the stated range.
By their numbers in this assay, from the lowest: compounds 3, 1 and 4 (each within the scatter of the next). At a limit, above all of these: compound 2.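

In this assay, cyclohexyl in place of isopropyl gives a 1.5-fold higher number from compound 3 to compound 4 (0.19 log units; within the scatter), and 2-cyclohexylphenyl in place of 2,4-diisopropylphenyl gives a 1.5-fold higher number from compound 1 to compound 4 (0.17 log units; within the scatter), so a six-membered non-aromatic ring is accepted on this aromatic carbon, ortho to a large group, with no change beyond the scatter. Cyclohexyl in place of hydrogen gives an at least 1.3-fold lower number from compound 2 to compound 4 (0.12 log units; that floor lies within the scatter), so a real difference from the unsubstituted phenyl is not established for cyclohexyl, as it is for isopropyl. Compound 2 gives only a limit: the limit of > 25000 nM in this assay, at which 1 of the 4 values shown sits.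

Going by these compounds, whether a methyl group, a phenyl ring or an amine at this place would keep the number level with compound 3 remains open.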